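The source may report more compounds than this note shows. Statements on the series, on what has been measured and on what is new or still open speak of the compounds shown alone.

Working notes on the series in an ADME assay on microsomes from liver (Homo sapiens) for metabolic stability, read by LC-MS, with a stated time of 10 min; a higher number here means that more of the compound is left, a lower number that less of the compound is left.

Of the compounds shown here, two have numbers so far. Compound 1, `CN(C[C@H]1Cc2c(cccc2N2CCN3CCC[C@H]3C2)CN1)[C@H]1CCCc2cccnc21`, gives 36.6% in this assay. Compound 2, `FC1(F)CCC(CN(C[C@H]2Cc3c(cccc3N3CCNCC3)CN2)[C@H]2CCCc3cccnc32)CC1`, gives 68.6% in this assay. Compound 1 thus stands lowest of the two numbers; the nearest is compound 2, which lies higher by a gap beyond the scatter. Among the measured compounds shown here, compounds 1 and 2 differ in more than one place, so no single step connects them, and only the two values themselves are known.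

Compound 3, `CCN1CCN(c2cccc3c2C[C@H](CN(C)[C@H]2CCCc4cccnc42)NC3)CC1`, is not yet measured. It differs from compound 1 in one place: a group of 8 heavy atoms (6 carbon, 2 nitrogen; one six-membered non-aromatic ring with 2 hetero atoms) in place of a group of 9 heavy atoms (7 carbon, 2 nitrogen; one five-membered non-aromatic ring with 1 hetero atom, one six-membered non-aromatic ring with 2 hetero atoms), on an aromatic carbon, the new group being 4-ethylpiperazin-1-yl on the aromatic carbon.

For the measured compounds named here, no measured step of this kind exists here. A modest rise in this assay is expected for the step of a number 9.4 percentage points higher from compound 1 to compound 3 (within the scatter), of a size that may not clear the scatter. Compound 3 is estimated at 46%, within 26% to 66%.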

Compound 3, percent of the compound remaining: 0%
Compound 3: the middle estimate sits 46 percentage points above what was measured; measured number below the stated range.
By their numbers in this assay, from the lowest: compound 3; then compound 1; then compound 2.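

In this assay, the aromatic carbon carrying this amine proves sensitive to the group placed there, with a number 36.6 percentage points lower from compound 1 to compound 3 (beyond the scatter). Replacing the fused group, which holds a five-membered and a six-membered non-aromatic ring, with 4-ethylpiperazin-1-yl leaves compound 3 at 0%, so a change confined to this one place can outweigh everything else shared with compound 1. Nothing available explains the size of this step.

Compound 3 alone cannot separate the ethyl group from the loss of the five-membered ring, so either feature may carry the step. A methyl, acetyl or cyclopropyl group on the same piperazine nitrogen, or a morpholin-4-yl group at this aromatic carbon, would be needed to tell how far the result extends.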